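Exchanging 3-methoxyphenyl for 4-fluorophenyl: compound 3 to compound 4

This account rests on a few compounds, and the source may have more. Where it says the series, first, only, none or still open, it means among the compounds named here.

In an ADME assay on THP-1 cells (Homo sapiens) for cytotoxicity, read by flow cytometry and propidium iodide staining, with a stated time of 72 h (on this read-out higher numbers stand for weaker inhibition and lower numbers for stronger inhibition), compound 3 (`COc1cccc(-c2oc3ccc(NC(C)=O)cc3c(=O)c2OC)c1`) gives 5000 nM and sits within the scatter of compound 1 (`COc1cccc(-c2cc(=O)c3cc(NC(C)=O)ccc3o2)c1`) at 10000 nM while compound 2 (`CC(=O)Nc1ccc2oc(-c3ccc(F)cc3)c(O)c(=O)c2c1`) reads higher at 26000 nM on the same scale.

Compound 4 (`COc1c(-c2ccc(F)cc2)oc2ccc(NC(C)=O)cc2c1=O`) changes one place of compound 3 (4-fluorophenyl in place of 3-methoxyphenyl on an aromatic carbon) with 4-fluorophenyl in place of 3-methoxyphenyl on an aromatic carbon next to the ring oxygen and ortho to a methoxy group.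

Among the compounds with values here, the one measured step is a 2.0-fold lower number from compound 1 to compound 3 (0.30 log units; within the scatter) for methoxy in place of hydrogen on an aromatic carbon, and it does not touch the exchanged group. Within the data shown here, no measured step isolates the exchange. Among the measured compounds shown here, compound 2 is the only measured compound with 4-fluorophenyl and its value of 26000 nM hints at a higher number, though it also differs from compound 3 in a second place.

The expected change is a 1.8-fold higher number from compound 3 to compound 4 (0.26 log units; within the scatter) in this assay as a small rise, with no firm step beyond the scatter. For compound 4 the estimated value is 9000 nM with an expected range from 4000 nM to 22000 nM as a working figure.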

Compound 4, half-maximal inhibitory concentration: > 125000 nM
Compound 4 was reported as a limit; the forecaster's own chance of this, stated with the estimate: 10%; middle value at least 13-fold (1.14 log units) from the limit.
By their numbers in this assay, from the lowest: compounds 3 and 1 (each within the scatter of the next); then compound 2. At a limit, above all of these: compound 4.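

In this assay compound 4 is reported only as a limit: the limit of > 125000 nM in this assay, at which 1 of the 4 values shown sits.

Within the data shown here, this gives the first isolated reading of the group on the carbon next to the ring oxygen: with the methoxy on the shared core kept, 4-fluorophenyl in place of 3-methoxyphenyl is a large step (an at least 25-fold higher number from compound 3 to compound 4 (1.39 log units; beyond the scatter)). In the 4-fluorophenyl pair, methyl in place of hydrogen on the oxygen also raises the number (an at least 4.8-fold higher number from compound 2 to compound 4 (0.68 log units; beyond the scatter)), yet compound 3 carries the same methoxy and reads 5000 nM, so that methoxy alone does not set the read-out.

On these data alone, the true size of both steps stays open, as each rests on a limit. The compounds shown also do not separate loss of the 3-methoxy group from gain of the fluorine, and an unsubstituted phenyl or a 3-aminophenyl at this position would bear on that.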